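Methoxy for cyano on the distal phenyl sulfone

The source may report more compounds than this note shows. Statements on the series, on what has been measured and on what is new or still open speak of the compounds shown alone.

Measured so far:
compound 1, `CC(O)(C(=O)Nc1ccc(S(=O)(=O)c2ccc(C#N)cc2)cc1)C(F)(F)F`: > 30000 nM
compound 2, `COc1cc(NC(=O)C(C)(O)C(F)(F)F)ccc1S(=O)(=O)c1ccccc1`: 5900 nM

In a functional assay (Cavia porcellus) with sulfonylurea receptors; K-ATP channels (Homo sapiens) as the target (a higher number here means a weaker inhibitor, a lower number a stronger inhibitor), compound 1 gives > 30000 nM, which is a limit of the assay and not a number. Compound 2 in this assay gives 5900 nM. Within the data shown here, compound 1 thus stands at the weak end of the two values shown, at the limit of > 30000 nM in this assay, at which 1 of the 2 values shown sits, while compound 2 is the only one of the pair with a measured number.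

Compound 3, `COc1ccc(S(=O)(=O)c2ccc(NC(=O)C(C)(O)C(F)(F)F)cc2)cc1`, differs from compound 1 by methoxy in place of cyano on an aromatic carbon. Among the measured compounds shown here, no step between two measured compounds covers this change, and the size of the step from compound 1 cannot be anchored, as compound 1 sets only a limit. A move toward stronger inhibition into the measurable range is expected, but a modest one, since compound 2 with 5900 nM is the only measurable reference in the series. Compound 3 is expected to give 15000 nM, in the range 4000 nM to 60000 nM. This corresponds to an expected step of an at least 2.0-fold lower number from compound 1 to compound 3 (0.30 log units; that floor lies within the scatter) in this assay.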

Compound 3, half-maximal inhibitory concentration: > 30000 nM
Compound 3: no number, only a limit; the forecaster's own chance of this, stated with the estimate: 40%; at least 2.0-fold (0.30 log units) between middle value and limit.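

Compound 3, like compound 1, gives only a limit and not a number in this assay, so no step can be read between them: the limit of > 30000 nM in this assay, at which 2 of the 3 values shown sit. The compounds shown leave open whether methoxy in place of cyano on an aromatic carbon changes inhibition at all.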